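The compounds below may be only part of what the source reports. "The series", "measured", "known", "first", "only" and "open" are said of these compounds alone.

In an ADME assay on MT4 cells (Homo sapiens) for cytotoxicity, read by MTT assay, with a stated time of 5 days (on this read-out higher numbers stand for lower toxicity in this test and lower numbers for higher toxicity in this test), compound 1 `Cc1cccc(Cn2cc(CNC(=O)c3cnc(Nc4ccc(C#N)cc4)cc3Oc3c(C)cc(C)cc3C)nn2)c1` gives 114000 nM, while compound 2 `CC(=O)Cn1cc(CNC(=O)c2cnc(Nc3ccc(C#N)cc3)cc2Oc2c(C)cc(C)cc2C)nn1` gives 19400 nM, the lowest of the two numbers shown; the step of a 5.9-fold lower number from compound 1 to compound 2 (0.77 log units; beyond the scatter) is the only measured step and lies beyond the scatter. Compound 3 `Cc1cc(C)c(Oc2cc(Nc3ccc(C#N)cc3)ncc2C(=O)NCc2cn(CCC#N)nn2)c(C)c1` differs from compound 2 by cyanomethyl in place of acetyl on a saturated chain carbon bound to an aromatic nitrogen. Within the data shown here, the one measured step changed a much larger group at the same place, so it bears only loosely on this swap of two small groups, and no step beyond the scatter is expected here. The step from compound 2 to compound 3 is expected to be a 1.3-fold higher number from compound 2 to compound 3 (0.11 log units; within the scatter). Compound 3 is therefore estimated at 25000 nM, within 9000 nM to 70000 nM.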

Compound 3, half-maximal cytotoxic concentration: 40200 nM
Estimate against measurement, compound 3: 1.6-fold (0.21 log units) below; measured number inside the range.
By their numbers in this assay, from the lowest: compound 2; then compound 3; then compound 1.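

In this assay, a swap between two small groups without a ring at this place, on a saturated chain carbon bound to an aromatic nitrogen, still moves the number, with cyanomethyl in place of acetyl giving a 2.1-fold higher number from compound 2 to compound 3 (0.32 log units; beyond the scatter). Cyanomethyl in place of 3-methylphenyl gives a 2.8-fold lower number from compound 1 to compound 3 (0.45 log units; beyond the scatter), so compound 1 keeps the highest number of the three, though compound 3 narrows the gap left by compound 2. Nothing available here accounts for either step. On these data alone, whether an amine, a carboxylic acid or a longer chain at this place would approach compound 1 remains open. So does whether other rings would match 3-methylphenyl.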